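From phenyl to 5-chlorothiophen-2-yl on a shared core

The compounds below may be only part of what the source reports. "The series", "measured", "known", "first", "only" and "open" are said of these compounds alone.

- Compound 1 (`Cc1nn(C)c2nc(NNC(=O)Nc3cc(Cl)nc(Cl)c3)cc(C3CC3)c12`) gives 67700 nM
- Compound 2 (`Cc1nn(C)c2nc(NNC(=O)Nc3cc(Cl)nc(Cl)c3)cc(C3CCCCC3)c12`) gives 38000 nM
- Compound 3 (`Cc1nn(C)c2nc(NNC(=O)Nc3cc(Cl)nc(Cl)c3)cc(-c3ccccc3)c12`) gives 80000 nM

In a functional assay on HCT-116 cells (Homo sapiens) for cytotoxicity, read by MTT assay, with a stated time of 48 h, in the presence of a further agent that is not named here (on this read-out lower numbers stand for an effect already at smaller amounts and higher numbers for an effect only at larger amounts of compound), compound 3 gives 80000 nM and stands level with compound 1 (a 1.2-fold higher number from compound 1 to compound 3 (0.07 log units; within the scatter)) but apart from compound 2 (a 2.1-fold higher number from compound 2 to compound 3 (0.32 log units; beyond the scatter)). The next change is 5-chlorothiophen-2-yl in place of phenyl on an aromatic carbon, which gives compound 4 (`Cc1nn(C)c2nc(NNC(=O)Nc3cc(Cl)nc(Cl)c3)cc(-c3ccc(Cl)s3)c12`). All measured steps at this same place were small, and the third was no exception (a 1.8-fold lower number from compound 1 to compound 2 (0.25 log units; within the scatter)). None of them involves a thiophene or a chlorine, so they guide the expectation only loosely. A similarly small step is therefore expected (estimated as a 1.5-fold lower number from compound 3 to compound 4 (0.16 log units; within the scatter)). Compound 4 is estimated at 55000 nM (expected range 22000 nM to 100000 nM).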

Compound 4, half-maximal effective concentration: 42100 nM
Compound 4: the middle estimate sits 1.3-fold (0.12 log units) above what was measured; the range from low to high includes it.
By their numbers in this assay, from the lowest: compounds 2, 4, 1 and 3 (each within the scatter of the next, the first and the last beyond it).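

In this assay the group 5-chlorothiophen-2-yl, the first here with a hetero atom in its ring and a chlorine, stays within the scatter against phenyl (a 1.9-fold lower number from compound 3 to compound 4 (0.28 log units; within the scatter)), against cyclohexyl (a 1.1-fold higher number from compound 2 to compound 4 (0.04 log units; within the scatter)) and against cyclopropyl (a 1.6-fold lower number from compound 1 to compound 4 (0.21 log units; within the scatter)). This sulfur-containing ring therefore does not set compound 4 apart from any of the other three compounds at this position. Nothing available explains this result.

From the compounds shown here alone, whether an amine or a carboxylic acid at this position would move the number beyond the scatter remains open.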